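Ring size on the amide nitrogen of compound 1

A few compounds are considered here, and "the series" means these few. Any claim that something is new, unique, unknown or untested is made for them only; others in the source may bear on it.

Compound 1 `O=C1c2ccc(C#Cc3ccccc3)nc2CCN1C1CCCC1` carries a cyclopentyl group on the amide nitrogen of its shared core. In a functional assay on HEK293 cells for positive allosteric modulation of metabotropic glutamate receptor 5 (Homo sapiens), read by FLIPR and calcium flux (a higher number here means that more compound is needed for the effect, a lower number that less compound is needed), compound 1 gives 5.9 nM, the lowest of the three numbers measured. Compound 3 `O=C1c2ccc(C#Cc3cccc(Cl)c3)nc2CCN1C1CCCC1` gives 33 nM, and compound 2 `O=C1c2ccc(C#Cc3ccccc3Cl)nc2CCN1C1CCCC1` gives 393 nM; the rises from compound 1 are a 5.6-fold higher number from compound 1 to compound 3 (0.75 log units; beyond the scatter) and a 67-fold higher number from compound 1 to compound 2 (1.82 log units; beyond the scatter), and between the two chlorinated compounds the step is a 12-fold lower number from compound 2 to compound 3 (1.08 log units; beyond the scatter).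

Compound 4 `O=C1c2ccc(C#Cc3ccccc3)nc2CCN1C1CCCCC1` is not yet measured. It differs from compound 1 by cyclohexyl in place of cyclopentyl on an amide-type nitrogen in a ring. All three measured steps alter the phenyl ring at the triple bond, not the group on the amide nitrogen, so none of them bears directly on this change. With nothing measured on this position, the expectation is a change within the usual scatter, so compound 4 is expected to give 8 nM, with a range of 2 nM to 35 nM, meaning an estimated step of a 1.4-fold higher number from compound 1 to compound 4 (0.13 log units; within the scatter).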

Compound 4, half-maximal effective concentration: 40 nM
Estimate against measurement, compound 4: 5.0-fold (0.70 log units) below, outside the stated range (above it).
By their numbers in this assay, from the lowest: compound 1; then compounds 3 and 4 (each within the scatter of the next); then compound 2.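

The group on the amide nitrogen is not a silent position: in this assay, going from cyclopentyl to cyclohexyl gives a 6.8-fold higher number from compound 1 to compound 4 (0.83 log units; beyond the scatter) for a single added ring carbon. The earlier compounds shown here varied only the phenyl ring at the triple bond, so this is a second place in the molecule where a small edit changes how much compound is needed. Nothing available here explains why this one change has an effect of this size.

Only two ring sizes are shown, so it stays open how a smaller ring such as cyclobutyl, an open chain such as isopropyl, or an oxygen-containing ring such as tetrahydropyranyl would compare with cyclopentyl. Also open, as far as these compounds go, is whether the chloro steps on the phenyl ring would look the same with cyclohexyl on the amide nitrogen.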